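Carbamate-Carbonate Variation on a Shared Core

A few compounds are considered here, and "the series" means these few. Any claim that something is new, unique, unknown or untested is made for them only; others in the source may bear on it.

Measured compounds in an assay on microsomes from intestine for inhibition of acyl-CoA:cholesterol acyltransferase (Oryctolagus cuniculus); on this read-out lower numbers stand for stronger inhibition and higher numbers for weaker inhibition:
compound 1 `COC(=O)C(OC(=O)NC(=O)Oc1c(C(C)C)cccc1C(C)C)c1ccccc1` gives 940 nM;
compound 2 `CC(C)c1cccc(C(C)C)c1OC(=O)NC(=O)OCc1ccccc1` gives 77 nM;
compound 3 `CCCCCCCCCCOC(=O)NC(=O)Oc1c(C(C)C)cccc1C(C)C` gives 74 nM.

Among these three numbers compound 2 stands second highest; its nearest neighbour is compound 3, and its furthest is compound 1. The step of a 12-fold lower number from compound 1 to compound 2 (1.09 log units; beyond the scatter) is large and lies beyond the scatter, whereas the step of a 1.0-fold lower number from compound 2 to compound 3 (0.02 log units; within the scatter) lies within it.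

Compound 4 `CC(C)c1cccc(C(C)C)c1OC(=O)NC(=O)SCc1ccco1` has not been measured. It differs from compound 2 in one place: ((furan-2-yl)methyl)sulfanyl in place of benzyloxy on a carbonyl carbon. Among the measured compounds shown here, of the measured steps, only the one from compound 2 to compound 3 touches the same region, the group on the far side of the carbonyl, and there the exchange of phenyl for nonyl left the number essentially unchanged. For the measured compounds named here, the exchange of one aromatic ring for another, together with sulfur for oxygen, has no direct precedent here, so the expected step in this assay is small, a 1.3-fold higher number from compound 2 to compound 4 (0.11 log units; within the scatter), with no clear direction beyond the scatter. Compound 4 is therefore estimated at 100 nM, within a range from 30 nM to 350 nM.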

Compound 4, half-maximal inhibitory concentration: 470 nM
The estimate for compound 4 lay 4.7-fold (0.67 log units) below the measured number; measured number outside the range, above it.
By their numbers in this assay, from the lowest: compounds 3 and 2 (each within the scatter of the next); then compounds 4 and 1 (each within the scatter of the next).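

In this assay, the end of the molecule on the carbonyl carbon whose other neighbour is the amide-type nitrogen proves sensitive to change: ((furan-2-yl)methyl)sulfanyl in place of benzyloxy gives a 6.1-fold higher number from compound 2 to compound 4 (0.79 log units; beyond the scatter), a weakening beyond the scatter. The earlier exchange in this region, a 1.0-fold lower number from compound 2 to compound 3 (0.02 log units; within the scatter), had given no such sign, so this end does not accept every replacement of benzyloxy equally. No measurement shown accounts for the weakening.

The new group differs from benzyloxy in both its ring and its linking atom, so the step cannot be divided between the furan and the sulfur. Benzylsulfanyl, which keeps the phenyl ring, and (furan-2-yl)methoxy, which keeps the oxygen, would each separate these two changes, and the compounds shown leave open which of them carries the loss.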